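Swapping Chloro for Cyano in a Cytotoxicity Screen

A few compounds are considered here, and "the series" means these few. Any claim that something is new, unique, unknown or untested is made for them only; others in the source may bear on it.

Compound 1 `COc1cc(NC(=O)c2ccc(Cl)cc2)ccc1NS(C)(=O)=O` and compound 2 `COc1cc(NC(=O)c2ccc(C#N)cc2)ccc1NS(C)(=O)=O` share one core, while compound 3 `O=C(Nc1ccc(NS(=O)(=O)C(F)(F)F)c(Cl)c1)c1ccc(Cl)cc1` and compound 4 `N#Cc1ccc(C(=O)Nc2ccc(NS(=O)(=O)C(F)(F)F)c(Cl)c2)cc1` share another; the difference between the two cores is not broken down here. In an ADME assay on HEK293 cells (Homo sapiens) for cytotoxicity, read by MTT assay, with a stated time of 48 h (a higher number here means a weaker inhibitor, a lower number a stronger inhibitor), compound 1 gives > 250000 nM, which is a limit of the assay and not a number. Compound 2 likewise gives > 250000 nM, again a limit. The change between them, (cyano in place of chloro on an aromatic carbon), therefore yields a step that the two limits leave unreadable from compound 1 to compound 2. Within the data shown here, compound 3 gives 191000 nM in this assay, the only real number among the three. The same change now carries compound 3 to compound 4 (cyano in place of chloro on an aromatic carbon). Among the measured compounds shown here, because the limit of > 250000 nM in this assay, at which 2 of the 3 values shown sit, is all that the measured pair shows, the size of this step cannot be read from it, and the only guide is that compound 3 itself sits close to that limit. Compound 4 is therefore expected to show a 1.2-fold higher number from compound 3 to compound 4 (0.08 log units; within the scatter), a step of roughly no size. The estimate for compound 4 is 230000 nM, between 120000 nM and 400000 nM, with a fair chance that only a limit is reported.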

Compound 4, half-maximal inhibitory concentration: > 250000 nM
Compound 4 gave a limit, no number; the forecaster's own chance of this, stated with the estimate: 45%; middle value at least 1.0-fold (0.03 log units) from the limit.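

In this assay, carrying cyano in place of chloro onto the second core gives an at least 1.3-fold higher number from compound 3 to compound 4 (0.11 log units; that floor lies within the scatter), so this core shows no fall in the number, though the floor of that step cannot separate the two compounds. Compound 4 gives > 250000 nM, which is a limit and not a number. The step on the core of compound 1 cannot be read, and whether the change has the same size on both cores remains unknown because nearly every value rests on one boundary: the limit of > 250000 nM in this assay, at which 3 of the 4 values shown sit.

The compounds shown leave open how large the chloro-to-cyano step really is, which would take a core on which both partners give a real number. They also leave open whether a different group in the same place, such as an amine or a carboxylic acid, would bring the number in this cell test clearly below that of compound 3.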